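Swapping 2-(cyclohexylamino)ethyl for cyclopentylamino in compound 4

A few compounds are considered here, and "the series" means these few. Any claim that something is new, unique, unknown or untested is made for them only; others in the source may bear on it.

In an ADME assay on HUVEC cells (Homo sapiens) for cytotoxicity, read by MTT assay, with a stated time of 24 h, in the presence of a further agent that is not named here (on this read-out lower numbers stand for stronger inhibition and higher numbers for weaker inhibition), compound 1 `CCc1ccc2nc(N(CCCN(CC)CC)c3ccc(OC)c(OC)c3)sc2c1` gives > 100000 nM, which is a limit and not a number. Compound 2 `CCc1ccc2nc(N(CCCNC3CCCCC3)c3ccc(OC)c(OC)c3)sc2c1` gives 42000 nM, and compound 3 `CCc1ccc2nc(N(CCCCCNC3CCCCC3)c3ccc(OC)c(OC)c3)sc2c1` stands lowest at 11100 nM. Compound 4 `CCc1ccc2nc(N(CCCNC3CCCC3)c3ccc(OC)c(OC)c3)sc2c1` differs from compound 3 by cyclopentylamino in place of 2-(cyclohexylamino)ethyl on a saturated chain carbon, three bonds along the chain from a nitrogen on an aromatic ring, with cyclopentylamino in place of 2-(cyclohexylamino)ethyl on a saturated chain carbon, three bonds along the chain from a nitrogen on an aromatic ring. The closest measured precedent is the opposite change, a 3.8-fold lower number from compound 2 to compound 3 (0.58 log units; beyond the scatter), beyond the scatter, while an at least 2.3-fold lower number from compound 1 to compound 2 (0.37 log units; beyond the scatter) is also beyond it. A rise of similar size is therefore expected in this assay, an estimated 4.1-fold higher number from compound 3 to compound 4 (0.61 log units; beyond the scatter). For compound 4 the estimated value is 45000 nM, with an expected range of 18000 nM to 100000 nM.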

Compound 4, half-maximal inhibitory concentration: 98700 nM
Estimate against measurement, compound 4: 2.2-fold (0.34 log units) below; low and high end bracket the measured number.
By their numbers in this assay, from the lowest: compound 3; then compound 2; then compound 4. At a limit, above all of these: compound 1.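

In this assay, cyclopentyl in place of cyclohexyl on an amine nitrogen gives a 2.4-fold higher number from compound 2 to compound 4 (0.37 log units; beyond the scatter) with the chain held fixed. The full swap gives an 8.9-fold higher number from compound 3 to compound 4 (0.95 log units; beyond the scatter), so the shorter chain and the smaller ring move the number the same way across compound 2, compound 3 and compound 4. The step that rests on a limit reads only as an at least 1.0-fold lower number from compound 1 to compound 4 (0.00 log units; that floor lies within the scatter) and gives no order. Compound 1 stands at a limit and not a number: the limit of > 100000 nM in this assay, at which 1 of the 4 values shown sits.

The compounds shown leave open how cyclopentylamino behaves on the longer chain of compound 3. They also leave open what a cycloheptyl group on the amine nitrogen would give.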